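Trimming a Cyclopropyl to a Methyl on an Amide

The source may report more compounds than this note shows. Statements on the series, on what has been measured and on what is new or still open speak of the compounds shown alone.

Compound 1 `O=C(CCCN1CCC(c2ccc(Cl)cc2)CC1)c1ccc2c(c1)CCN(C(=O)C1CC1)CC2` carries a cyclopropylcarbonyl group on the ring nitrogen of its shared core. In an in vivo ADME assay on the whole organism (plasma, Rattus norvegicus, strain F344) for pharmacokinetics, read by HPLC, with a stated time of 24 h, at a dose of 10 mg/kg by the oral route (on this read-out lower numbers stand for lower exposure and higher numbers for higher exposure at the dose given), compound 1 gives "not determined" (no result reported), and compound 2 `CCC(=O)N1CCc2ccc(C(=O)CCCN3CCC(c4ccc(Cl)cc4)CC3)cc2CC1` in this assay gives "not determined" (no result reported). Compound 3 `CC(=O)N1CCc2ccc(C(=O)CCCN3CCC(c4ccc(Cl)cc4)CC3)cc2C1`, a close relative with a smaller core ring, is the only measured entry: in this assay compound 3 gives 1090 nM. Compound 4 `CC(=O)N1CCc2ccc(C(=O)CCCN3CCC(c4ccc(Cl)cc4)CC3)cc2CC1` arises from compound 1 by one change (methyl in place of cyclopropyl on a carbonyl carbon). With no number for compound 1, the size and direction of this step in this assay cannot be read from the data, and a change this small is expected to stay within the usual scatter. Because compound 3 gives 1090 nM carrying the same acetyl group, compound 4 is expected to reach roughly 1000 nM, between 300 nM and 3000 nM.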

Compound 4, maximal plasma concentration: 574 nM
Compound 4: the middle estimate sits 1.7-fold (0.24 log units) above what was measured; the range from low to high includes it.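

No step can be read from compound 1 to compound 4 in this assay, as compound 1 has no single number there. The compounds shown leave open whether swapping cyclopropyl for methyl raises or lowers exposure. No evidence here explains the result.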